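The source may hold more compounds than are shown below. What is called first, only, known or untested is meant among the compounds shown, and "the series" means these compounds.

Compound 3 `C[C@H]1CC[C@@H]2[C@@H](OC(=O)[C@]23CC(c2ccc(Br)cc2)N(c2ccccc2)O3)[C@]2(C)C(=O)C=C[C@@]12O` stands highest of the three compounds measured in a physicochemical assay for lipophilicity (on this read-out lower numbers stand for lower lipophilicity and higher numbers for higher lipophilicity), where compound 3 gives 4. Compound 1 `C[C@H]1CC[C@@H]2[C@@H](OC(=O)[C@]23CC(c2ccccc2)=NO3)[C@]2(C)C(=O)C=C[C@@]12O` gives 1.41 in this assay, and compound 2 `COc1ccc(C2=NO[C@]3(C2)C(=O)O[C@@H]2[C@H]3CC[C@H](C)[C@]3(O)C=CC(=O)[C@@]23C)cc1OC` gives 1.06, so both lie far under compound 3. Going by the values given here, the single measured step, a number 0.35 log units lower from compound 1 to compound 2 (beyond the scatter), changed the aromatic group on a carbon with a double bond to nitrogen, and it is only a loose guide here. Compound 4 `C[C@H]1CC[C@@H]2[C@@H](OC(=O)[C@]23CC(c2c(F)cccc2F)N(c2ccccc2)O3)[C@]2(C)C(=O)C=C[C@@]12O` differs from compound 3 by 2,6-difluorophenyl in place of 4-bromophenyl on a saturated ring carbon. Among the compounds with values here, no measured step covers this exchange directly; since the one aromatic exchange seen was modest, a modest fall in this assay is expected, a number 0.50 log units lower from compound 3 to compound 4 (beyond the scatter). Compound 4 is expected to give 3.5, between 3 and 4.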

Compound 4, partition coefficient: 3.42
The estimate for compound 4 lay 0.08 log units above the measured number; low and high end bracket the measured number.
By their numbers in this assay, from the lowest: compound 2; then compound 1; then compound 4; then compound 3.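

The exchange on this saturated ring carbon, with the phenyl group on the ring nitrogen unchanged, gives a number 0.58 log units lower from compound 3 to compound 4 (beyond the scatter) in this assay. It shows that this position of the five-membered ring with nitrogen and oxygen also responds to an aromatic exchange, which the earlier step, made on a carbon with a double bond to nitrogen, could not show. Nothing available explains the size of this step. The compounds shown leave open whether the bromine or the two fluorines set this step, which a plain phenyl or a 4-fluorophenyl at this carbon could separate. As far as these compounds go, how an amine or a carboxylic acid would read here also remains open.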